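From bromo to phenyl: compound 2 to compound 3

A few compounds are considered here, and "the series" means these few. Any claim that something is new, unique, unknown or untested is made for them only; others in the source may bear on it.

Compound 1 `O=C(CCCCCCCc1cc(-c2cccnc2)on1)Nc1ccccc1-c1ccccc1` gives 59.8 nM
Compound 2 `O=S(=O)(NCCCCCCCn1cc(-c2cccnc2)nn1)c1ccccc1Br` gives 162 nM

Both numbers come from a functional assay on SH-SY5Y cells (Homo sapiens) for cytotoxicity, read by MTT assay, with a stated time of 56 h (on this read-out higher numbers stand for an effect only at larger amounts of compound and lower numbers for an effect already at smaller amounts), and only these two compounds have been measured so far. Compound 2 stands higher at 162 nM than compound 1 at 59.8 nM and this gap lies beyond the scatter. Compound 3 `O=S(=O)(NCCCCCCCn1cc(-c2cccnc2)nn1)c1ccccc1-c1ccccc1` has phenyl in place of bromo on an aromatic carbon of compound 2 (phenyl in place of bromo on an aromatic carbon). For the measured compounds named here, no measured pair shows this change, so its size can only be judged loosely. Going by the values given here, the one hint is that compound 1 at 59.8 nM also carries phenyl on an aromatic carbon, although it differs from compound 2 elsewhere as well. In this assay a modest step toward a lower number is therefore expected, and it may stay within the scatter. The estimated change is a 1.6-fold lower number from compound 2 to compound 3 (0.21 log units; within the scatter) for this swap. For compound 3 the expected value is 100 nM on this estimate (40 nM to 250 nM).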

Compound 3, half-maximal effective concentration: 99.2 nM
Beside the measured number, compound 3's estimate is 1.0-fold (0.00 log units) above it; measured number inside the range.
By their numbers in this assay, from the lowest: compounds 1, 3 and 2 (each within the scatter of the next, the first and the last beyond it).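

In this assay, for the compounds shown here, the first pair that differs only at this place, phenyl in place of bromo on an aromatic carbon, shows a 1.6-fold lower number from compound 2 to compound 3 (0.21 log units; within the scatter). The earlier compounds shown here could not show this, since compound 1 and compound 2 differ in more than one place, and the carbon concerned, ortho to a large group, now proves to carry either a single bromine or a whole six-membered aromatic ring with no difference that can be told from the scatter. The measured data offer no independent information that could explain this outcome.

Going by these compounds, this reading rests on a single pair, so it remains open whether an amine, a carboxylic acid or a methoxy group at this place would likewise stay within the scatter, or whether a pyridyl ring would read like phenyl. On these data alone, it is also open whether the same swap would give a similar step with a shorter or longer chain, or in the core of compound 1.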